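Swapping Thiophene for Phenyl on a Weak Growth Inhibitor

The source may hold more compounds than are shown below. What is called first, only, known or untested is meant among the compounds shown, and "the series" means these compounds.

Measured so far:
Compound 1, `CC1CCCc2c1nc(N)c(C#N)c2-c1cccn1C`: 69100 nM
Compound 2, `Cn1cccc1-c1cc(-c2cccs2)[nH]c(=O)c1C#N`: a limit of the assay, > 100000 nM
Compound 3, `COc1ccc(-c2cc(-c3cccn3C)c(C#N)c(N)n2)cc1OC`: 64600 nM

In a functional assay on BT-549 cells (Homo sapiens) for inhibition, read by sulforhodamine B assay, with a stated time of 48 h (a lower number here means a stronger inhibitor of growth, a higher number a weaker inhibitor of growth), compound 1 gives 69100 nM, and compound 3 gives 64600 nM. Compound 2 stands apart from these two, because for compound 2 no number is known, only (the limit of > 100000 nM in this assay, at which 1 of the 3 values shown sits). Compound 2 therefore sits at the weak end of what has been seen.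

The next compound, compound 4 with the structure `Cn1cccc1-c1cc(-c2ccccc2)[nH]c(=O)c1C#N`, differs from compound 2 in one place: phenyl in place of thiophen-2-yl on an aromatic carbon. Within the data shown here, no pair of measured compounds shows this particular change, so there is no measured step to lean on. Since compound 2 is itself at the limit of > 100000 nM, the expected step from compound 2 to compound 4 is none beyond the scatter, a step that the limit leaves unreadable from compound 2 to compound 4. Compound 4 is accordingly expected to give about 120000 nM, within a range from 30000 nM to 500000 nM, and a further limit rather than a number is the most likely outcome.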

Compound 4, concentration for 50% growth inhibition: 85100 nM
For compound 4 the middle estimate is 1.4-fold (0.15 log units) above the measured one; low and high end bracket the measured number.
By their numbers in this assay, from the lowest: compounds 3, 1 and 4 (each within the scatter of the next). At a limit, above all of these: compound 2.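

In this assay, phenyl in place of thiophen-2-yl on this aromatic carbon, next to the ring nitrogen, gives an at least 1.1-fold lower number from compound 2 to compound 4 (0.07 log units; that floor lies within the scatter). With phenyl in this place, compound 4 gives a real number, 85100 nM, so this core now has one value that can serve as a starting point for later comparisons. The printed floor alone does not show a real gain, and the full size of the step cannot be read, because compound 2 has only a limit: the limit of > 100000 nM in this assay, at which 1 of the 4 values shown sits.

The compounds shown leave open whether any group on this carbon can bring the number down clearly in this assay. An amine or a carboxylic acid in this place, for example, would test whether an aromatic ring is needed here at all.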